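Working notes: from compound 2 to compound 3

The compounds below may be only part of what the source reports. "The series", "measured", "known", "first", "only" and "open" are said of these compounds alone.

Measured compounds, with values from an ADME assay on the whole organism (plasma) for pharmacokinetics, with Rattus norvegicus as the target, with a stated time of 6 h, at a dose of 10 mg/kg by the oral route; a higher number here means more compound in the circulation at the dose given, a lower number less compound in the circulation
- compound 1 `Cc1cn2c(-c3cn[nH]c3)cnc2c(Nc2cc(CN3CCCCC3(C)C)ns2)n1` gives 211 ng.h/mL
- compound 2 `Cc1cn2c(-c3cn[nH]c3)cnc2c(Nc2cc(CN3CCN(C)C(=O)C3)ns2)n1` gives "not determined" (no result reported)

Compound 2 has no number in this assay and so gives no baseline. Compound 3 `Cc1cn2c(-c3cn[nH]c3)cnc2c(Nc2cc(CN3C[C@H](C)OC[C@@H]3C)ns2)n1` carries this structural change: a group of 8 heavy atoms (6 carbon, 1 nitrogen, 1 oxygen; one six-membered non-aromatic ring with 2 hetero atoms) in place of a group of 8 heavy atoms (5 carbon, 2 nitrogen, 1 oxygen; one six-membered non-aromatic ring with 2 hetero atoms), on a saturated chain carbon bound to an aromatic carbon. With no value for compound 2, no size or direction of step from it can be expected. Among the measured compounds shown here, the only numerical anchor is compound 1 (211 ng.h/mL), and no difference from it beyond the usual scatter is expected. For compound 3 the estimated value is 300 ng.h/mL, with an expected range from 90 ng.h/mL to 1000 ng.h/mL.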

Compound 3, area under the concentration-time curve: 1660 ng.h/mL
Estimate against measurement, compound 3: 5.5-fold (0.74 log units) below, and the stated range ends below it.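

In this assay, the group on the saturated chain carbon bound to an aromatic carbon clearly affects the read-out: a six-membered non-aromatic ring with 2 hetero atoms and 2 defined stereocentres, in place of the group that compound 1 carries there, gives a 7.9-fold higher number from compound 1 to compound 3 (0.90 log units; beyond the scatter) at this place. Compound 2 has no value, so steps involving it cannot be read. Nothing on hand explains the rise. Still open, from the compounds shown here alone, is whether the 2 defined stereocentres matter, and how an unsubstituted morpholine or an open-chain dimethylamine would read here.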